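Shrinking the Amide Substituent: Cyclopropyl for Cyclopropylphenyl

The compounds below may be only part of what the source reports. "The series", "measured", "known", "first", "only" and "open" are said of these compounds alone.

Compound 1 `CN1C[C@H](C(=O)Nc2ccc(C3CC3)cc2)[C@@H](c2ccc(/C=C/C(=O)Nc3ccccc3N)cc2)C1` carries a 4-cyclopropylphenyl group on its amide-type nitrogen. In an in vitro ADME assay on microsomes from liver (Homo sapiens) for pharmacokinetics, read by LC-MS, with a stated time of 10 min, tested at 1 uM (on this read-out higher numbers stand for fast clearance and lower numbers for slow clearance), compound 1 gives 12 mL/min/kg. Compound 2 `CN1C[C@H](C(=O)Nc2ccc(F)c(Br)c2)[C@@H](c2ccc(/C=C/C(=O)Nc3ccccc3N)cc2)C1` shares the same core but bears a 3-bromo-4-fluorophenyl at that place, and in this assay compound 2 gives 15 mL/min/kg. Among the compounds with values here, the step of a 1.3-fold higher number from compound 1 to compound 2 (0.10 log units; within the scatter) shows that exchanging one six-membered aromatic ring for another barely moves the read-out, so on the two numbers so far compound 1 sits within the scatter of compound 2 rather than apart from it.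

Compound 3 `CN1C[C@H](C(=O)NC2CC2)[C@@H](c2ccc(/C=C/C(=O)Nc3ccccc3N)cc2)C1` makes a different kind of change: cyclopropyl in place of 4-cyclopropylphenyl on an amide-type nitrogen. The six-membered aromatic ring is removed entirely and only the three-membered ring stays on the nitrogen. Within the data shown here, no measured step tests removing that ring; the one step known at this position, between two aromatic groups, stayed within the scatter. Going by these compounds, the expected step is a 1.2-fold lower number from compound 1 to compound 3 (0.08 log units; within the scatter), estimated to fall within the scatter, though with real uncertainty because the change is untested. For compound 3 the estimate in this assay is 10 mL/min/kg, with a range from 5 mL/min/kg to 22 mL/min/kg.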

Compound 3, clearance: 10 mL/min/kg
Compound 3: middle estimate and measured number agree at the digits printed; the measured number falls inside the stated range.
By their numbers in this assay, from the lowest: compounds 3, 1 and 2 (each within the scatter of the next).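

Within the data shown here, until now, the only comparison at this position was one aromatic group against another. Compound 3 adds that the six-membered aromatic ring can be removed altogether, leaving just cyclopropyl on the amide-type nitrogen, and this assay still shows only a 1.2-fold lower number from compound 1 to compound 3 (0.08 log units; within the scatter) for that change. The comparison with the halogen-bearing group reads the same way, at a 1.5-fold lower number from compound 2 to compound 3 (0.18 log units; within the scatter), so across these three compounds neither the presence of the aromatic ring nor the choice of group on it separates the clearance numbers, and no supporting data here explain why.

Going by these compounds, all three groups on this nitrogen contain a ring, so it remains open whether a longer chain, an amine or a carboxylic acid at the same place would also stay within the scatter. The shared core is also the same throughout, so these compounds cannot show whether the same tolerance would hold with a change elsewhere in the molecule.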